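A few compounds are considered here, and "the series" means these few. Any claim that something is new, unique, unknown or untested is made for them only; others in the source may bear on it.

Of the compounds shown here, three have so far been measured in an assay on isolated protein for inhibition of Hematopoietic prostaglandin D synthase (Homo sapiens); on this read-out lower numbers stand for stronger inhibition and higher numbers for weaker inhibition. Compound 1 `CNS(=O)(=O)c1cccc(CNC(=O)c2cnc(-c3cccc(F)c3)nc2C)c1` gives 9.5 nM, compound 2 `CC(C)(CO)NS(=O)(=O)c1cccc(CNC(=O)c2cnc(-c3cccc(F)c3)nc2)c1` gives 23 nM, and compound 3 `Cc1nc(-c2ccccn2)ncc1C(=O)Nn1ccc2c(C(F)(F)F)cccc21` gives 10 nM. Among these numbers compound 3 sits close to compound 1, a gap within the usual scatter, while compound 2 gives a higher number, a gap beyond it. Compound 4 `Cc1nc(-c2ncccn2)ncc1C(=O)Nn1ccc2c(C(F)(F)F)cccc21` differs from compound 3 in one place: pyrimidin-2-yl in place of pyridin-2-yl on an aromatic carbon. For the measured compounds named here, no measured pair shows this change, so its size cannot be read from the data at hand. The expectation is a small step, a 1.2-fold higher number from compound 3 to compound 4 (0.08 log units; within the scatter), most likely within the scatter in either direction. Compound 4 is therefore estimated at 12 nM, with a range from 4 nM to 40 nM.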

Compound 4, half-maximal inhibitory concentration: 8 nM
For compound 4 the middle estimate is 1.5-fold (0.18 log units) above the measured one, and the stated range covers the measured number.
By their numbers in this assay, from the lowest: compounds 4, 1 and 3 (each within the scatter of the next); then compound 2.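

In this assay, putting pyrimidin-2-yl in place of pyridin-2-yl gives a 1.3-fold lower number from compound 3 to compound 4 (0.10 log units; within the scatter) and so shows that, on this aromatic carbon between two ring nitrogen atoms, a second ring nitrogen and an extra hydrogen-bond acceptor leave the number practically unmoved. No measurement at hand explains why these two rings read alike. Still open, on these data alone, is whether a non-aromatic group here, such as morpholine or a simple amine, would read the same. Also open, as far as these compounds go, is whether this swap behaves alike on other cores.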